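Chloro on the Phenyl of Compound 3: Expected Effect

A few compounds are considered here, and "the series" means these few. Any claim that something is new, unique, unknown or untested is made for them only; others in the source may bear on it.

Compound 1 `COc1cccc(C(O)CCn2nc3c(Br)c(Br)c(Br)c(Br)c3n2)c1`: 6%
Compound 2 `C[C@@H](O)CCn1nc2c(Br)c(Br)c(Br)c(Br)c2n1`: 0%
Compound 3 `OC(CCn1nc2c(Br)c(Br)c(Br)c(Br)c2n1)c1ccccc1`: 0%

In a functional assay on MCF7 cells (Homo sapiens) for antiproliferative activity, read by MTT assay, with a stated time of 48 h, tested at 100 uM (a lower number here means a stronger effect, a higher number a weaker effect of the compound at the concentration tested), compound 3 gives 0%, level with compound 2 at the digits shown; together they are the lowest of the three numbers. Compound 1 gives 6%, which lies within the scatter of compound 3. Compound 4 `OC(CCn1nc2c(Br)c(Br)c(Br)c(Br)c2n1)c1ccc(Cl)cc1` differs from compound 3 by chloro in place of hydrogen on an aromatic carbon. Among the measured compounds shown here, only one measured step concerns a substituent on that phenyl: a number 6 percentage points lower from compound 1 to compound 3 (within the scatter), which stayed within the scatter. For the measured compounds named here, no measured compound carries a halogen on that ring, so the data offer no direct precedent. Compound 4 is therefore expected to show no step beyond the scatter, a number 3 percentage points higher from compound 3 to compound 4 (within the scatter). The estimate for compound 4 is 3%, expected to fall between 0% and 15%.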

Compound 4, a percentage reported as activity, at one concentration (the size of the read-out at that concentration, not a potency): 0%
Compound 4: the middle estimate sits 3 percentage points above what was measured, within the range that was stated.
By their numbers in this assay, from the lowest: compounds 2, 3, 4 and 1 (each within the scatter of the next).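

In this assay, the first halogen on this phenyl, a chloro para to a large group, gives no change at the digits printed from compound 3 to compound 4 (within the scatter). Exchanging the whole aryl group gives a number 6 percentage points lower from compound 1 to compound 4 (within the scatter), so neither the chloro nor the 3-methoxyphenyl to 4-chlorophenyl change moves the number beyond the scatter. The data offer no explanation for this result. Going by these compounds, it remains open whether an amine or a carboxylic acid on this ring would shift the number beyond the scatter. On these data alone, the effect of a longer chain on the core also remains open.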